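Cytotoxicity on hepatoma cells: aryl isoxazole series, third analogue

A few compounds are considered here, and "the series" means these few. Any claim that something is new, unique, unknown or untested is made for them only; others in the source may bear on it.

Measured so far:
compound 1 `O=[N+]([O-])c1ccc(CN2CCC(n3cc(CC(OCc4cc(-c5ccc(Br)cc5)no4)c4ccc(Br)cc4)nn3)CC2)cc1` – 2000 nM
compound 2 `N#Cc1ccc(-c2cc(COC(Cc3cn(C4CCN(Cc5ccc([N+](=O)[O-])cc5)CC4)nn3)c3ccc(Br)cc3)on2)cc1` – 5000 nM

Among the compounds with values here, in a functional assay on Huh-7 cells (Homo sapiens) for cytotoxicity, with a stated time of 48 h (on this read-out lower numbers stand for stronger inhibition and higher numbers for weaker inhibition), compound 2 gives 5000 nM, the higher of the two numbers; the nearest neighbour is compound 1, and the single measured step is a 2.5-fold higher number from compound 1 to compound 2 (0.40 log units; beyond the scatter). Compound 3 `COc1cccc(-c2cc(COC(Cc3cn(C4CCN(Cc5ccc([N+](=O)[O-])cc5)CC4)nn3)c3ccc(Br)cc3)on2)c1` differs from compound 2 by 3-methoxyphenyl in place of 4-cyanophenyl on an aromatic carbon. Within the data shown here, no measured step exchanges the 4-cyanophenyl for a 3-methoxyphenyl, so the only guide is that one substituent exchange on this aryl ring moved this assay by a modest amount. A step of similar size, in either direction, is therefore plausible, and no direction can be called likely; a return toward the number of compound 1 is the expectation adopted here. Compound 3 is estimated at 3500 nM, range 1200 nM to 10000 nM, a step of a 1.4-fold lower number from compound 2 to compound 3 (0.15 log units; within the scatter) that is expected but not secured by data.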

Compound 3, half-maximal inhibitory concentration: 5000 nM
For compound 3 the middle estimate is 1.4-fold (0.15 log units) below the measured one; low and high end bracket the measured number.
By their numbers in this assay, from the lowest: compound 1; then compounds 2 and 3 (each within the scatter of the next).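

In this assay, 3-methoxyphenyl in place of 4-cyanophenyl gives no change at the digits printed from compound 2 to compound 3 (within the scatter), so these two aryl groups are not separated at this position on the five-membered aromatic ring. 3-Methoxyphenyl in place of 4-bromophenyl gives a 2.5-fold higher number from compound 1 to compound 3 (0.40 log units; beyond the scatter), the same printed size as the earlier step to the cyano analogue, which leaves compound 1 alone at the low end of the three numbers. No available evidence bears on this result.

Within the data shown here, with only three aryl groups in hand, the effect of the substituent cannot be told apart from that of its place on the ring. Going by these compounds, it also remains open whether an amine or a carboxylic acid on this aryl ring would move the number away from the level of compound 2 and compound 3.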